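The compounds below may be only part of what the source reports. "The series", "measured", "known", "first", "only" and "open" are said of these compounds alone.

- Compound 1 `C[C@H]1CCCCC(CCCC(Cl)Cl)c2c(O)cc(cc2O)[C@H](OC(N)=O)[C@@H](C)CCCCC(CCCC(Cl)Cl)c2c(O)cc(cc2O)[C@@H]1OC(N)=O`: 3300 nM
- Compound 2 `C[C@H]1CCCCC(CCCCCl)c2c(O)cc(cc2O)[C@H](OC(N)=O)[C@@H](C)CCCCC(CCCC(Cl)Cl)c2c(O)cc(cc2O)[C@@H]1OC(N)=O`: 4200 nM

Both values come from an ADME assay on F1 cells (Homo sapiens) for cytotoxicity, with a stated time of 48 h; on this read-out higher numbers stand for weaker inhibition and lower numbers for stronger inhibition. Among the compounds with values here, with only two measurements, compound 2 at 4200 nM cannot be separated from its one neighbour: the measured step, a 1.3-fold higher number from compound 1 to compound 2 (0.10 log units; within the scatter), is no larger than repeat measurements would give.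

The next compound is compound 3 `CCCCC1CCCC[C@H](C)[C@@H](OC(N)=O)c2cc(O)c(c(O)c2)C(CCCC(Cl)Cl)CCCC[C@H](C)[C@@H](OC(N)=O)c2cc(O)c1c(O)c2`, not yet measured. Its change from compound 2 is hydrogen in place of chloro on a saturated chain carbon, four bonds along the chain from a saturated ring carbon. In plain words, one more chlorine gives way to hydrogen on a chain.

Within the data shown here, only one measured step bears on this, a 1.3-fold higher number from compound 1 to compound 2 (0.10 log units; within the scatter), which was also hydrogen in place of chloro on a saturated chain carbon. In that step the carbon was bound to a further chlorine atom, so the match is close but not exact, and a single small step is thin evidence. On that basis no shift beyond the scatter is expected in this assay, and any drift would most likely continue in the same direction. The expected step is a 1.2-fold higher number from compound 2 to compound 3 (0.08 log units; within the scatter). For compound 3 the estimated value is 5000 nM, with an expected range of 2500 nM to 10000 nM.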

Compound 3, half-maximal inhibitory concentration: 5100 nM
Beside the measured number, compound 3's estimate is 1.0-fold (0.01 log units) below it; measured number inside the range.
By their numbers in this assay, from the lowest: compounds 1, 2 and 3 (each within the scatter of the next).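

In this assay, this chain can lose its last chlorine, at the carbon four bonds along the chain from a saturated ring carbon, with only a 1.2-fold higher number from compound 2 to compound 3 (0.08 log units; within the scatter). Read as a single change, dichloromethyl to methyl gives a 1.5-fold higher number from compound 1 to compound 3 (0.19 log units; within the scatter), so even with both chlorines gone from this chain, the number cannot be told apart from repeat measurements of the same compound. Nothing measured here explains why the number moves so little.

Going by these compounds, the dichloromethyl group on the other chain is still present in all three compounds, so it remains open whether the number would stay within the scatter if that group also gave way to methyl. Also open, on these data alone, is what an amine, a carboxylic acid or a longer chain would do at the position studied here, as chlorine and hydrogen are the only atoms compared there.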